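The source may report more compounds than this note shows. Statements on the series, on what has been measured and on what is new or still open speak of the compounds shown alone.

Compound 1 `COc1ccccc1C1C(C#N)=C(N)N(c2ccc(S(N)(=O)=O)cc2)C2=C1CCCC2` and compound 2 `COc1ccc(C2C(C#N)=C(N)N(c3ccc(S(N)(=O)=O)cc3)C3=C2CCCC3)cc1` share one core and differ only in the aryl group on a saturated ring carbon. In a functional assay on Ehrlich cells (Mus musculus) for cytotoxicity, read by trypan blue exclusion, with a stated time of 2 h, tested at 100 ug/mL (a higher number here means a stronger effect of the compound at the concentration tested, a lower number a weaker effect), compound 1 gives 100%, and compound 2 gives 100% in this assay. The step of no change at the digits printed from compound 1 to compound 2 (within the scatter) shows that compound 2 stands level with compound 1 on this read-out. Compound 3 `N#CC1=C(N)N(c2ccc(S(N)(=O)=O)cc2)C2=C(CCCC2)C1c1cccc([N+](=O)[O-])c1` has not been measured yet. It differs from compound 2 by 3-nitrophenyl in place of 4-methoxyphenyl on a saturated ring carbon. Within the data shown here, only one measured step exists, no change at the digits printed from compound 1 to compound 2 (within the scatter), and it swapped one methoxyphenyl for another; no measured step exchanges a methoxy group for a nitro group, so the weight of this change is unknown. The values of compound 1 and compound 2 already sit at the top of the scale, which leaves no room for a rise. For compound 3 a step of about a number 5 percentage points lower from compound 2 to compound 3 (within the scatter) is expected in this assay. Compound 3 is estimated at 95%, within 75% to 100%.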

Compound 3, a percentage reported as activity, at one concentration (the size of the read-out at that concentration, not a potency): 12%
The estimate for compound 3 lay 83 percentage points above the measured number, and the stated range ends above it.
By their numbers in this assay, from the lowest: compound 3; then compounds 1 and 2 (each within the scatter of the next).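

In this assay, putting 3-nitrophenyl in place of 4-methoxyphenyl on the saturated ring carbon gives a number 88 percentage points lower from compound 2 to compound 3 (beyond the scatter), and putting it in place of 2-methoxyphenyl gives a number 88 percentage points lower from compound 1 to compound 3 (beyond the scatter). The two methoxyphenyl compounds alone could suggest that this position accepts changes freely, but both sit at the top of the scale, and the new result shows that the group held here can decide the read-out. No measurement at hand explains the fall.

The compounds shown do not separate the nitro group itself from its place on the phenyl ring, so a 3-methoxyphenyl or a 4-nitrophenyl group would be the telling comparison. Going by these compounds, how an unsubstituted phenyl or a 3-aminophenyl group would read at this position also stays open.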